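This account rests on a few compounds, and the source may have more. Where it says the series, first, only, none or still open, it means among the compounds named here.

Compounds 1, 2 and 3 share one core and differ only in the aryl group attached to the sulfonyl sulfur: compound 1 is `CNC(=O)c1cc(Oc2ccc(NS(=O)(=O)c3ccc([N+](=O)[O-])cc3)cc2)ccn1`, compound 2 is `CNC(=O)c1cc(Oc2ccc(NS(=O)(=O)c3ccc(F)cc3)cc2)ccn1` and compound 3 is `CNC(=O)c1cc(Oc2ccc(NS(=O)(=O)c3ccc(C(F)(F)F)cc3Br)cc2)ccn1`. In a functional assay on PLC-PRF-5 cells (Homo sapiens) for inhibition (on this read-out lower numbers stand for stronger inhibition and higher numbers for weaker inhibition), compound 1 gives only a limit of the assay, > 40000 nM. Compound 2 likewise gives only a limit in this assay, > 40000 nM. Compound 3 also stops at a limit in this assay, > 40000 nM. Compound 2 therefore stands where its two companions stand: at the limit, with no number that would set it apart from either. The one step that pairs two of these compounds, a step that the two limits leave unreadable from compound 1 to compound 2, cannot be sized, because the limit of > 40000 nM in this assay, at which 3 of the 3 values shown sit, holds both of its ends.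

Compound 4 is `CNC(=O)c1cc(Oc2ccc(NS(=O)(=O)c3ccccc3[N+](=O)[O-])cc2)ccn1`. It differs from compound 2 by 2-nitrophenyl in place of 4-fluorophenyl on a sulfonyl sulfur. Among the compounds with values here, the only measured step that touches a nitro group on this aryl ring, the one from compound 1 to compound 2, yields no readable size, and compound 1 itself reaches nothing but the limit. Nothing among the numbers points to a gain. Compound 4 is therefore expected to sit at the limit as well, with an estimated value of 60000 nM, ranging from 20000 nM to 200000 nM, so that the expected step that the limit leaves unreadable from compound 2 to compound 4 stays within the scatter.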

Compound 4, half-maximal inhibitory concentration: > 40000 nM
Compound 4: a limit, no number (the forecaster's own chance of this, stated with the estimate: 85%); the middle value is on the limit's open side.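

In this assay compound 4 gives only a limit, > 40000 nM. The steps from compound 2 and from compound 1 to compound 4 cannot be read, because both ends of each sit at one limit: the limit of > 40000 nM in this assay, at which 4 of the 4 values shown sit. The compounds shown leave open whether any aryl group on the sulfonyl sulfur of the shared core gives a numerical value in this assay.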